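Benzyl for Phenyl: Expectation for Compound 3

The source may hold more compounds than are shown below. What is called first, only, known or untested is meant among the compounds shown, and "the series" means these compounds.

This account follows a single change made to compound 2 `O=C(O)c1ccccc1-c1ccc(CCc2ncc(-c3ccccc3)[nH]2)cc1` in an in vitro functional assay on cells for agonist activity at Bombesin receptor subtype-3 (Homo sapiens), read by luminescence and calcium flux; a higher number here means that more compound is needed for the effect, a lower number that less compound is needed. Of the compounds shown here, two have been measured. Compound 1 `O=C(O)c1ccccc1-c1ccc(CCc2ncc(CCC3CCCCC3)[nH]2)cc1` gives 642 nM, and compound 2 gives 4950 nM, which is the highest of the two numbers, with compound 1 its nearest neighbour. Within the data shown here, the only measured step, a 7.7-fold higher number from compound 1 to compound 2 (0.89 log units; beyond the scatter), runs in the direction of a higher number when the 2-cyclohexylethyl group is exchanged for phenyl. Compound 3 `O=C(O)c1ccccc1-c1ccc(CCc2ncc(Cc3ccccc3)[nH]2)cc1` differs from compound 2 by benzyl in place of phenyl on an aromatic carbon. Among the measured compounds shown here, no measured step bears directly on this change; the one step available shows only that the group on this aromatic carbon matters beyond the scatter. Compound 3 is therefore expected to land between the two measured values, with an estimated 2.0-fold lower number from compound 2 to compound 3 (0.30 log units; within the scatter). The estimate for compound 3 in this assay is 2500 nM, within a range from 600 nM to 10000 nM.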

Compound 3, half-maximal effective concentration: 205 nM
Compound 3: the middle estimate sits 12-fold (1.09 log units) above what was measured, outside the stated range (below it).
By their numbers in this assay, from the lowest: compound 3; then compound 1; then compound 2.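

The exchange of phenyl for benzyl on this aromatic carbon keeps the six-membered aromatic ring of carbon only and adds one heavy atom, yet it brings a 24-fold lower number from compound 2 to compound 3 (1.38 log units; beyond the scatter) in this assay, whereas the earlier compounds had shown only that the group here matters. Benzyl also compares well with the 2-cyclohexylethyl group, with a 3.1-fold lower number from compound 1 to compound 3 (0.50 log units; beyond the scatter), so compound 3 holds the lowest number of the three and this position does not need the saturated ring to reach it. Nothing measured here accounts for the size of these steps.

Going by these compounds, whether the gain would hold for 2-phenylethyl, a longer chain ending in the same ring, or for cyclohexylmethyl, stays open. So does the effect of a methoxy group or a fluorine on the benzyl ring.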